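Swapping the aryl thioether cap on a benzamide series

A few compounds are considered here, and "the series" means these few. Any claim that something is new, unique, unknown or untested is made for them only; others in the source may bear on it.

Of the compounds shown here, two from this set have been tested in a functional assay on A-375 cells (Homo sapiens) for inhibition, read by CCK-8 assay, with a stated time of 72 h, tested at 2 uM; on this read-out higher numbers stand for more inhibition of growth at the one concentration tested and lower numbers for less inhibition of growth. Compound 1, `Nc1ccccc1NC(=O)/C=C/c1ccc(CSc2ccc(Cl)cc2)cc1`, gives 13.4%, the lowest of the two numbers. Compound 2, `CCc1ccc(SCc2ccc(C(=O)Nc3ccccc3N)cc2)cc1`, gives 19.6%, a reading that sits within the usual scatter of the value for compound 1, so the two cannot be told apart on these data.

Compound 3, `Nc1ccccc1NC(=O)/C=C/c1ccc(CSc2ccc(C(F)(F)F)cn2)cc1`, shares the core of compound 1 and differs from it at a single place: 5-(trifluoromethyl)pyridin-2-yl in place of 4-chlorophenyl on a sulfur. Going by the values given here, no pair of measured compounds that differ in one place is available, so the size of this step has to be judged from the measured values alone. Both measured compounds show little growth inhibition in this assay, and nothing in the two values points to a change of the sulfur-linked aryl group moving the number far in either direction. The step from compound 1 to compound 3 is therefore expected to stay within the scatter, with a slight rise as the most likely outcome, a number 4.6 percentage points higher from compound 1 to compound 3 (within the scatter). Compound 3 is estimated to give 18% in this assay, with a range from 5% to 35%.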

Compound 3, percent growth inhibition at one concentration: 10.3%
Beside the measured number, compound 3's estimate is 7.7 percentage points above it; the range from low to high includes it.
By their numbers in this assay, from the lowest: compounds 3, 1 and 2 (each within the scatter of the next).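

In this assay, going by these compounds alone, the first step that can be read at this position, 5-(trifluoromethyl)pyridin-2-yl in place of 4-chlorophenyl on a sulfur, comes out as a number 3.1 percentage points lower from compound 1 to compound 3 (within the scatter) on the shared core of compound 1. The entering group differs from the one it replaces in several counted ways, with a ring holding one hetero atom, one hydrogen-bond acceptor and more heavy atoms, yet this reading does not separate compound 3 from compound 1, so at this position these differences taken together leave no mark that can be told from the scatter. Nothing on hand bears on why the number holds through this change.

Within the data shown here, the single step cannot say whether the ring hetero atom and the trifluoromethyl group each leave the reading alone or offset one another, since the two arrive together. It also leaves open whether an aryl group carrying an amine or a carboxylic acid, or a longer chain on the sulfur in place of the aryl group, would move the number beyond the scatter in this assay on this core.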